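This account rests on a few compounds, and the source may have more. Where it says the series, first, only, none or still open, it means among the compounds named here.

Compound 1 `Nc1nc(N2CCN(S(=O)(=O)c3ccccc3)CC2)c2nc(-c3ccc(F)cc3)sc2n1`: in a functional assay on cells (Lymphocyte, Homo sapiens) (a higher number here means a weaker inhibitor, a lower number a stronger inhibitor), compound 1 gives only a limit of the assay, > 10000 nM.
Compound 2 `CCCCCN1CCN(c2nc(N)nc3sc(-c4ccc(F)cc4)nc23)CC1`: in this assay compound 2 also gives only a limit, > 10000 nM.
Compound 3 `Nc1nc(N2CCN(C(=O)COc3ccccc3)CC2)c2nc(-c3ccc(F)cc3)sc2n1`: in this assay compound 3 gives 90 nM.

Compound 3 is the only one of the three with a real number; the other two sit at the assay limit (the limit of > 10000 nM in this assay, at which 2 of the 3 values shown sit). Compound 4 `Nc1nc(N2CCN(C(=O)COc3ccc(F)cc3)CC2)c2nc(-c3ccc(F)cc3)sc2n1` differs from compound 3 by fluoro in place of hydrogen on an aromatic carbon. Within the data shown here, none of the measured steps touches this ring: an at least 110-fold lower number from compound 1 to compound 3 (2.04 log units; beyond the scatter) and an at least 110-fold lower number from compound 2 to compound 3 (2.04 log units; beyond the scatter) swap the entire group on the ring nitrogen, and a step that the two limits leave unreadable from compound 1 to compound 2 cannot be read. The step is therefore expected to stay within the scatter, no change at the digits printed from compound 3 to compound 4 (within the scatter). Compound 4 is estimated at 90 nM, between 40 nM and 200 nM.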

Compound 4, half-maximal inhibitory concentration: 70 nM
Beside the measured number, compound 4's estimate is 1.3-fold (0.11 log units) above it, within the range that was stated.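

In this assay, among these compounds, fluoro on this aromatic carbon of the phenoxy ring makes no change beyond the scatter (a 1.3-fold lower number from compound 3 to compound 4 (0.11 log units; within the scatter)), so this ring, untouched by the earlier steps, accepts this small change. The large difference from the two inactive compounds also holds with the fluoro in place (an at least 140-fold lower number from compound 2 to compound 4 (2.15 log units; beyond the scatter)) and (an at least 140-fold lower number from compound 1 to compound 4 (2.15 log units; beyond the scatter)). Both of these steps start from a limit rather than a number: the limit of > 10000 nM in this assay, at which 2 of the 4 values shown sit.

The compounds shown leave open how a methoxy, a carboxylic acid or an amine at this position would behave. They also leave open whether a fluoro elsewhere on this ring would be accepted in the same way.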